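This account rests on a few compounds, and the source may have more. Where it says the series, first, only, none or still open, it means among the compounds named here.

Measured so far:
Compound 1 `[O-][S+](CCCCN=C=S)C1CCCC1`: 4600 nM
Compound 2 `[O-][S+](CCCCN=C=S)Cc1ccccc1`: 4850 nM

In an ADME assay on Vero cells (Chlorocebus sabaeus) for cytotoxicity, read by MTT assay, with a stated time of 72 h (a higher number here means a weaker inhibitor, a lower number a stronger inhibitor), compound 2 at 4850 nM lies within the usual scatter of compound 1, so these two values cannot be told apart. Compound 3 `COc1ccc(C[S+]([O-])CCCCN=C=S)cc1` differs from compound 2 in one place: methoxy in place of hydrogen on an aromatic carbon. The new methoxy sits on an aromatic carbon, para to a large group. Going by the values given here, no measured pair shows this change, so the expectation in this assay is no shift beyond the scatter, in either direction. The estimated change is small: a 1.1-fold lower number from compound 2 to compound 3 (0.03 log units; within the scatter). For compound 3 the expected value is 4500 nM, with an estimated range of 2000 nM to 10000 nM.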

Compound 3, half-maximal inhibitory concentration: 3710 nM
Estimate against measurement, compound 3: 1.2-fold (0.08 log units) above; low and high end bracket the measured number.
By their numbers in this assay, from the lowest: compounds 3, 1 and 2 (each within the scatter of the next).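

In this assay, methoxy in place of hydrogen on an aromatic carbon, para to a large group, gives a 1.3-fold lower number from compound 2 to compound 3 (0.12 log units; within the scatter) and so cannot be told apart from no change. Going by these compounds alone, this is the first measured pair with one change at this position, and it shows that adding methoxy here leaves the cytotoxicity reading within the scatter. Nothing measured here explains this result.

Going by these compounds, whether an amine or a carboxylic acid at this position would move the number beyond the scatter remains open. So does the outcome of methoxy on another carbon of the ring.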